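From Trifluoromethoxy to Methoxy on a Shared Core

The source may hold more compounds than are shown below. What is called first, only, known or untested is meant among the compounds shown, and "the series" means these compounds.

Three compounds sharing one core and differing in a single group on an aromatic carbon have been measured in a functional assay on HOP-62 cells (Homo sapiens) for inhibition, read by sulforhodamine B assay; a lower number here means a stronger inhibitor of growth, a higher number a weaker inhibitor of growth. Compound 1 `Fc1ccc(-c2ccc(-c3ccc(-c4nc5ccccc5[nH]4)cc3)cc2)cc1`, which carries fluoro, gives 39300 nM. Compound 2 `FC(F)(F)c1ccc(-c2ccc(-c3ccc(-c4nc5ccccc5[nH]4)cc3)cc2)cc1`, which carries trifluoromethyl, gives 100000 nM. Compound 3 `FC(F)(F)Oc1ccc(-c2ccc(-c3ccc(-c4nc5ccccc5[nH]4)cc3)cc2)cc1`, which carries trifluoromethoxy, gives 100000 nM, level with compound 2, and together they hold the highest number of the three.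

Compound 4 `COc1ccc(-c2ccc(-c3ccc(-c4nc5ccccc5[nH]4)cc3)cc2)cc1` has methyl in place of trifluoromethyl on an oxygen on an aromatic ring, so trifluoromethoxy becomes methoxy: methyl in place of trifluoromethyl on an oxygen on an aromatic ring. Among the measured compounds shown here, no measured compound carries methoxy, so the evidence is indirect. Exchanging fluoro for trifluoromethoxy gave a 2.5-fold higher number from compound 1 to compound 3 (0.41 log units; beyond the scatter), and exchanging fluoro for trifluoromethyl gave a 2.5-fold higher number from compound 1 to compound 2 (0.41 log units; beyond the scatter). Exchanging trifluoromethyl for trifluoromethoxy gave no change at the digits printed from compound 2 to compound 3 (within the scatter). The group changes measured so far have therefore moved the number only modestly, so a small move toward a lower number is expected here, probably not beyond the scatter. The expected change is a 1.8-fold lower number from compound 3 to compound 4 (0.26 log units; within the scatter). In this assay, compound 4 is estimated at 55000 nM, within an expected range of 25000 nM to 100000 nM.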

Compound 4, concentration for 50% growth inhibition: 100000 nM
The estimate for compound 4 lay 1.8-fold (0.26 log units) below the measured number; the measured number falls inside the stated range.
By their numbers in this assay, from the lowest: compound 1; then compounds 2, 3 and 4 (each within the scatter of the next).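

In this assay, exchanging trifluoromethyl for methyl on an oxygen on an aromatic ring left the number in place (step: no change at the digits printed from compound 3 to compound 4 (within the scatter)), which shows that removing the fluorines from this oxygen-linked group has no readable effect here. Methoxy and trifluoromethyl on the aromatic carbon also could not be told apart (step: no change at the digits printed from compound 2 to compound 4 (within the scatter)), whereas methoxy in place of fluoro gave a modest move (step: a 2.5-fold higher number from compound 1 to compound 4 (0.41 log units; beyond the scatter)), so compound 1 now stands apart from three compounds rather than two, and methoxy joins trifluoromethyl and trifluoromethoxy on the side of the weaker inhibitors of growth. Nothing at hand bears on why these three groups read alike or why fluoro differs from them.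

The compounds shown leave open whether any group at this place, such as an amine, a carboxylic acid or a longer alkoxy chain, would give a number lower than that of compound 1. They also leave open whether a bare hydrogen on this aromatic carbon would read with fluoro or with the other three groups.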